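Swapping chloro for fluoro at the limit of the assay

This account rests on a few compounds, and the source may have more. Where it says the series, first, only, none or still open, it means among the compounds named here.

Compound 1 `CCOC(=O)c1ccc(-c2nn(C)c3ccccc23)cc1` gives > 10000 nM as a limit
Compound 2 `CCOC(=O)c1ccc(-c2nn(Cc3cccc(Cl)c3)c3ccccc23)cc1` gives > 10000 nM as a limit

In a functional assay on cells (Platelet, Homo sapiens) for inhibition (a higher number here means a weaker inhibitor, a lower number a stronger inhibitor), compound 2 gives > 10000 nM as a limit, not a number. Compound 1 also stands at a limit, and the limit of > 10000 nM in this assay, at which 2 of the 2 values shown sit, is all that the pair shows.

Compound 3 `CCOC(=O)c1ccc(-c2nn(Cc3cccc(F)c3)c3ccccc23)cc1` differs from compound 2 at one place (fluoro in place of chloro on an aromatic carbon), where the 3-chlorobenzyl group becomes 3-fluorobenzyl. For the measured compounds named here, the one measured step (a step that the two limits leave unreadable from compound 1 to compound 2) has no readable size, and no measured step exchanges fluoro for chloro. No shift beyond the scatter can therefore be expected in this assay in either direction, and the expectation stays close to the limit of compound 2. Compound 3 is expected at about 10000 nM within an estimated range from 2000 nM to 20000 nM as the likely span. The expected step is (a number no higher from compound 2 to compound 3 (the limit leaves the size open)). A bare limit for compound 3 is also quite possible.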

Compound 3, half-maximal inhibitory concentration: > 10000 nM
Compound 3: a limit, no number; the forecaster's own chance of this, stated with the estimate: 65%; the middle value lies on the limit itself.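

Compound 3 gives > 10000 nM in this assay, which is a limit and not a number. No step among compound 1, compound 2 and compound 3 can therefore be read: the limit of > 10000 nM in this assay, at which 3 of the 3 values shown sit.

The compounds shown leave open how strongly any of the three inhibits in this assay, and whether 3-chlorobenzyl and 3-fluorobenzyl differ at all.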